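The compounds below may be only part of what the source reports. "The series", "measured", "known", "first", "only" and "open" are said of these compounds alone.

Working notes on the series in a functional assay on T29Kt1 cells (Homo sapiens) for cytotoxicity, read by sulforhodamine B assay, with a stated time of 3 days; on this read-out higher numbers stand for weaker inhibition and lower numbers for stronger inhibition. Compound 1 (`OCc1cn(Cc2ccc(Cl)cc2)c2ccccc12`) gives 79 nM, and compound 2 (`O=[N+]([O-])c1ccc(Cn2cc(CO)c3ccccc32)cc1`) gives 150 nM. Within the data shown here, these two numbers lie within the scatter of each other, so compound 2 stands level with compound 1, the only other measured compound. The next change leads to compound 3 (`COc1ccc(Cn2cc(CO)c3ccccc32)cc1`): methoxy in place of nitro on an aromatic carbon. This is methoxy in place of nitro on an aromatic carbon, para to a large group. Among the measured compounds shown here, one measured step bears on it, on the same aromatic carbon: a 1.9-fold higher number from compound 1 to compound 2 (0.28 log units; within the scatter), with nitro in place of chloro. For the measured compounds named here, that step stays within the scatter, and it is the only evidence available for changes at this carbon. Since chloro and nitro give numbers that cannot be told apart, no shift beyond the scatter is expected in this assay, and a single step supports no direction. The expected step is a 1.5-fold lower number from compound 2 to compound 3 (0.18 log units; within the scatter). For compound 3 the estimated value is 100 nM, with an expected range of 35 nM to 300 nM.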

Compound 3, half-maximal inhibitory concentration: 63 nM
For compound 3 the middle estimate is 1.6-fold (0.20 log units) above the measured one; the range from low to high includes it.
By their numbers in this assay, from the lowest: compounds 3, 1 and 2 (each within the scatter of the next, the first and the last beyond it).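

At this aromatic carbon, para to a large group, the series now shows its first step beyond the scatter in this assay (a 2.4-fold lower number from compound 2 to compound 3 (0.38 log units; beyond the scatter)), though a modest one, whereas the earlier exchange of chloro for nitro stayed within it. Methoxy and chloro cannot be told apart here (a 1.3-fold lower number from compound 1 to compound 3 (0.10 log units; within the scatter)), so the three groups do not fall into a clear order: only nitro and methoxy are separated, and chloro stands level with both. The data at hand offer no measurement that could account for the separation of nitro and methoxy, and the step remains an observation without an explanation.

The compounds shown leave open how an amine, a carboxylic acid or a longer chain such as butoxy would read at this carbon in this assay, and so whether any group moves the number further than methoxy does. They also leave open whether the step from nitro to methoxy would hold with any other part of the shared core changed.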